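This account rests on a few compounds, and the source may have more. Where it says the series, first, only, none or still open, it means among the compounds named here.

Compound 3 `CCCN(CCC)CCCCOc1ccc(C(=O)/C=C/c2ccccc2)cc1` stands in a physicochemical assay for lipophilicity, using the shake flask method, measured as octanol-water partition, at pH 7.4 (a higher number here means a more lipophilic compound, a lower number a more polar compound), at 1.95, the second highest of the three numbers shown. Compound 2 `CCCCN(CCCC)CCCOc1ccc(C(=O)/C=C/c2ccccc2)cc1` gives 2.06, and compound 1 `CN(C)CCCOc1ccc(C(=O)/C=C/c2ccccc2)cc1` gives 1.59. Compound 4 `CCN(CC)CCCCCOc1ccc(C(=O)/C=C/c2ccccc2)cc1` differs from compound 3 by (diethylamino)methyl in place of dipropylamino on a saturated chain carbon, four bonds along the chain from an oxygen on an aromatic ring. Among the measured compounds shown here, the steps that bear on this all change the amine substituents along the same chain: a number 0.36 log units higher from compound 1 to compound 3 (beyond the scatter) and a number 0.47 log units higher from compound 1 to compound 2 (beyond the scatter), both modest and beyond the scatter, while a number 0.11 log units lower from compound 2 to compound 3 (within the scatter) stays within the scatter. The change to compound 4 is of the same kind as the last of these, and a step within the scatter, if anything slightly lower, is expected, as a number 0.15 log units lower from compound 3 to compound 4 (within the scatter). Compound 4 is therefore estimated at 1.8, with a range of 1.5 to 2.1.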

Compound 4, partition coefficient: 1.84
The estimate for compound 4 lay 0.04 log units below the measured number; the measured number falls inside the stated range.
By their numbers in this assay, from the lowest: compounds 1, 4, 3 and 2 (each within the scatter of the next, the first and the last beyond it).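

In this assay, (diethylamino)methyl in place of dipropylamino, four bonds along the chain from an oxygen on an aromatic ring, gives a step that stays inside the scatter (a number 0.11 log units lower from compound 3 to compound 4 (within the scatter)). The other two steps also stay inside it (a number 0.22 log units lower from compound 2 to compound 4 (within the scatter); a number 0.25 log units higher from compound 1 to compound 4 (within the scatter)), so compound 4 cannot be separated from compound 1 or compound 2, although those two are separated from each other. No measurement at hand gives a reason for this.

Still open, on these data alone, is how a morpholine or piperidine ring in place of the open-chain amine would read in this assay, and whether a carboxylic acid in place of the amine would fall outside the span of these four compounds.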